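The source may hold more compounds than are shown below. What is called first, only, known or untested is meant among the compounds shown, and "the series" means these compounds.

Of the compounds shown here, three built on one shared core have been measured in an ADME assay on GES1 cells (Homo sapiens) for cytotoxicity, read by MTT assay, with a stated time of 24 h; a higher number here means that more compound is tolerated, a lower number that less compound is tolerated. Compound 1 `Cc1ccccc1-n1cc(-c2cccc(NS(=O)(=O)c3c[nH]c(=O)[nH]c3=O)c2)nn1` gives 21500 nM; compound 2 `Cc1ccc(-n2cc(-c3cccc(NS(=O)(=O)c4c[nH]c(=O)[nH]c4=O)c3)nn2)cc1` gives 15800 nM; compound 3 `O=c1[nH]cc(S(=O)(=O)Nc2cccc(-c3cn(-c4cccc(Cl)c4)nn3)c2)c(=O)[nH]1` gives 26200 nM. Compound 3 holds the highest of the three numbers, yet its distances to compound 1 and to compound 2 both lie within the scatter, so no real ranking emerges. Compound 4 `O=c1[nH]cc(S(=O)(=O)Nc2cccc(-c3cn(-c4ccc(Cl)cc4)nn3)c2)c(=O)[nH]1` is not yet measured; it differs from compound 3 by 4-chlorophenyl in place of 3-chlorophenyl on an aromatic nitrogen. The earlier swaps of the group on that same aromatic nitrogen bear directly on this change: a 1.4-fold lower number from compound 1 to compound 2 (0.13 log units; within the scatter), a 1.2-fold higher number from compound 1 to compound 3 (0.09 log units; within the scatter) and a 1.7-fold higher number from compound 2 to compound 3 (0.22 log units; within the scatter), none beyond the scatter. A step no larger than the scatter is therefore expected, a 1.1-fold lower number from compound 3 to compound 4 (0.04 log units; within the scatter). For compound 4 the expected value in this assay is 24000 nM, estimated to fall between 12000 nM and 48000 nM.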

Compound 4, half-maximal cytotoxic concentration: 11300 nM
Compound 4: middle estimate off by 2.1-fold (0.33 log units), on the high side; the measured number lies below the stated range.
By their numbers in this assay, from the lowest: compounds 4, 2, 1 and 3 (each within the scatter of the next, the first and the last beyond it).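

In this assay, going by these compounds alone, the place of the chlorine on the phenyl ring counts: with the same atoms joined differently there is a 2.3-fold lower number from compound 3 to compound 4 (0.37 log units; beyond the scatter) and this is the first swap on that aromatic nitrogen to pass the scatter. The 4-chlorophenyl group does not stand apart from either methylphenyl group, with a 1.4-fold lower number from compound 2 to compound 4 (0.15 log units; within the scatter) and a 1.9-fold lower number from compound 1 to compound 4 (0.28 log units; within the scatter) both within the scatter. Nothing measured here explains the shift. From the compounds shown here alone, how 2-chlorophenyl would compare with the other two chlorophenyl groups stays open, as does the outcome for a phenyl carrying an amine or a carboxylic acid.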